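Arylsulfonyl Variation on a Shared Core in KYSE-510 Cells

This account rests on a few compounds, and the source may have more. Where it says the series, first, only, none or still open, it means among the compounds named here.

Compound 1, `O=S(=O)(NC1=NCCN1C(=S)SN1CCn2c1nsc2=S)c1ccccc1`, gives >= 20000 nM in this assay.
Compound 2, `COc1ccc(OC)c(S(=O)(=O)NC2=NCCN2C(=S)SN2CCn3c2nsc3=S)c1`, gives >= 20000 nM in this assay.

Compound 1 carries phenyl on the sulfonyl sulfur, and in a functional assay on KYSE-510 cells (Homo sapiens) for antiproliferative activity, read by crystal violet staining, with a stated time of 96 h (on this read-out higher numbers stand for weaker inhibition of growth and lower numbers for stronger inhibition of growth), its value is only a limit of the assay, not a number. Compound 2 carries 2,5-dimethoxyphenyl in the same place, and in this assay its value is likewise only a limit. The step that the two limits leave unreadable from compound 1 to compound 2 therefore cannot be read, as both values sit at the same limit (the limit of >= 20000 nM in this assay, at which 2 of the 2 values shown sit). Compound 3, `O=[N+]([O-])c1ccc(S(=O)(=O)NC2=NCCN2C(=S)SN2CCn3c2nsc3=S)cc1`, differs from compound 2 by 4-nitrophenyl in place of 2,5-dimethoxyphenyl on a sulfonyl sulfur. Within the data shown here, the only measured step touching the sulfonyl sulfur is a step that the two limits leave unreadable from compound 1 to compound 2, and being unreadable it gives no direction for the change to 4-nitrophenyl. With both measured compounds at the limit, compound 3 is expected to stay at the limit too, a step of a number no higher from compound 2 to compound 3 (the limit leaves the size open). The estimate for compound 3 in this assay is 20000 nM, with a range from 8000 nM to 40000 nM.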

Compound 3, concentration for 50% growth inhibition: >= 20000 nM
Compound 3 ended at the assay's limit (the forecaster's own chance of this, stated with the estimate: 80%); the middle value lies on the limit itself.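

Among these compounds, compound 1, compound 2 and compound 3 all stand at a limit of the assay, not at a number, so no step among them can be read: the limit of >= 20000 nM in this assay, at which 3 of the 3 values shown sit. The compounds shown leave open how changing the group on the sulfonyl sulfur affects growth inhibition.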